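The source may hold more compounds than are shown below. What is called first, only, known or untested is meant among the compounds shown, and "the series" means these compounds.

In an assay on SW1353 cells (Homo sapiens) for inhibition, read by a luciferase reporter, with stated times of 30 min and 8 h (on this read-out lower numbers stand for stronger inhibition and higher numbers for weaker inhibition), compound 1 (`O=c1oc2ccccc2n1CCCCCN1CCN(CCCCCn2c(=O)oc3ccccc32)CC1`) gives 3430 nM, which lies within the scatter of compound 2 (`O=c1sc2ccccc2n1CCCCCCN1CCN(CCn2c(=O)sc3ccccc32)CC1`) at 2950 nM and of compound 3 (`O=c1sc2ccccc2n1CCCCCCN1CCN(CCCn2c(=O)sc3ccccc32)CC1`) at 2400 nM. Compound 4 (`O=c1oc2ccccc2n1CCCCCCN1CCN(CCCCCn2c(=O)oc3ccccc32)CC1`) differs from compound 1 by a group of 11 heavy atoms (8 carbon, 1 nitrogen, 2 oxygen; one five-membered aromatic ring with 2 hetero atoms, one six-membered aromatic ring of carbon only) in place of a group of 10 heavy atoms (7 carbon, 1 nitrogen, 2 oxygen; one five-membered aromatic ring with 2 hetero atoms, one six-membered aromatic ring of carbon only), on a saturated chain carbon, five bonds along the chain from an amine nitrogen in a ring. For the measured compounds named here, one measured step bears on this change: a 1.2-fold lower number from compound 2 to compound 3 (0.09 log units; within the scatter). It also puts a group of 11 heavy atoms in place of a group of 10 heavy atoms, though the groups contain sulfur and the place is two bonds along the chain, and it stays within the scatter. No step beyond the scatter is therefore expected in this assay. The expected step is a 1.2-fold lower number from compound 1 to compound 4 (0.07 log units; within the scatter). For compound 4 the estimated value is 2900 nM, with an expected range of 1500 nM to 5500 nM.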

Compound 4, half-maximal inhibitory concentration: 1400 nM
The estimate for compound 4 lay 2.1-fold (0.32 log units) above the measured number; the whole stated range lies above it.
By their numbers in this assay, from the lowest: compounds 4, 3, 2 and 1 (each within the scatter of the next, the first and the last beyond it).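

In this assay, the group of 11 heavy atoms in place of the group of 10 heavy atoms, five bonds along the chain from an amine nitrogen in a ring, gives a 2.5-fold lower number from compound 1 to compound 4 (0.39 log units; beyond the scatter). The corresponding exchange two bonds along the chain, in the sulfur-containing pair, gives a 1.2-fold lower number from compound 2 to compound 3 (0.09 log units; within the scatter), so this kind of exchange does not always stay within the scatter. No available data explain the step. On these data alone, it remains open whether a longer chain at this place lowers the number further, and whether a hydroxyl group on the chain keeps the inhibition.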